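The compounds below may be only part of what the source reports. "The series", "measured", "known", "first", "only" and "open" are said of these compounds alone.

Of the compounds shown here, three sharing one core have been measured in a physicochemical assay for lipophilicity; a lower number here means a more polar compound, a higher number a more lipophilic compound. Compound 1 (`c1ccc(CC2CCC3(CC2)OOCCCOO3)cc1`) gives 3.93, compound 2 (`FC(F)(F)c1ccc(CC2CCC3(CC2)OOCCCOO3)cc1`) gives 4.79, and compound 3 (`COC(=O)c1ccc(CC2CCC3(CC2)OOCCCOO3)cc1`) gives 3.75. Compound 3 therefore stands level with compound 1, the measured step being a number 0.18 log units lower from compound 1 to compound 3 (within the scatter), and well under compound 2, the measured step being a number 1.04 log units lower from compound 2 to compound 3 (beyond the scatter).

Compound 4 (`CS(=O)(=O)c1ccc(CC2CCC3(CC2)OOCCCOO3)cc1`) has not yet been measured. It carries methylsulfonyl in place of methoxycarbonyl on an aromatic carbon, para to a large group: methylsulfonyl in place of methoxycarbonyl on an aromatic carbon. All three measured steps concern this same place on the core. Besides the two already given, there is a number 0.86 log units higher from compound 1 to compound 2 (beyond the scatter), so exchanging the group here has moved the number by a modest or a large amount in two of the three cases. Within the data shown here, none of the measured compounds carries methylsulfonyl, so the direction of the change rests on the structural exchange alone. A large move to a lower number is expected in this assay, similar in size to the widest measured step, a number 1.04 log units lower from compound 2 to compound 3 (beyond the scatter). The expected step is a number 1.05 log units lower from compound 3 to compound 4 (beyond the scatter). Compound 4 is estimated at 2.7, within an expected range from 2.2 to 3.3.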

Compound 4, partition coefficient: 2.65
The estimate for compound 4 lay 0.05 log units above the measured number; low and high end bracket the measured number.
By their numbers in this assay, from the lowest: compound 4; then compounds 3 and 1 (each within the scatter of the next); then compound 2.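

In this assay, among these compounds, methylsulfonyl is the first group at this place, on an aromatic carbon para to a large group, to bring a large fall from hydrogen, with a number 1.28 log units lower from compound 1 to compound 4 (beyond the scatter) against only a number 0.18 log units lower from compound 1 to compound 3 (within the scatter) for methoxycarbonyl, a step that stays within the scatter. The exchange of methoxycarbonyl for methylsulfonyl leaves the counts of heavy atoms, hydrogen-bond donors and hydrogen-bond acceptors unchanged, yet it still gives a number 1.10 log units lower from compound 3 to compound 4 (beyond the scatter) and so shows that two groups alike in those counts can stand far apart in this assay. The span at this one place also widens, since a number 2.14 log units lower from compound 2 to compound 4 (beyond the scatter) exceeds the widest earlier step, which was a number 1.04 log units lower from compound 2 to compound 3 (beyond the scatter) and so shows that the choice of group here can shift the number further than the first three compounds revealed.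

As far as these compounds go, whether a sulfonamide, a carboxylic acid or an amine at this place would reach as low as compound 4 remains open, as does whether the same exchange would give a similar step elsewhere on the shared core. The data shown offer no explanation for the size of these steps.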